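A few compounds are considered here, and "the series" means these few. Any claim that something is new, unique, unknown or untested is made for them only; others in the source may bear on it.

In a functional assay (aorta) with Oryctolagus cuniculus as the target (a lower number here means tighter binding, a higher number weaker binding), compound 1 `COc1cc(C(C)=O)ccc1OCCCN1CCC(C(c2cccc(F)c2)c2cccc(F)c2)CC1` gives 3.16 nM.
In this assay compound 2 `COc1cc(C(C)=O)ccc1OCCCN1CCC(C(NC(C)=O)(c2ccc(F)cc2)c2ccc(F)cc2)CC1` gives 63.1 nM.
In this assay compound 3 `COc1cc(C(=O)O)ccc1OCCCN1CCC(C(c2ccc(F)cc2)c2ccc(F)cc2)CC1` gives 79.4 nM.

Compound 3 stands at the highest number of the three. Its nearest neighbour is compound 2, whose number lies within the usual scatter of that of compound 3, so the two cannot be ordered. Compound 1 lies well beyond the scatter on the lower side and is the only one of the three clearly apart from compound 3. Compound 1 and compound 3 differ in more than one place, so their gap cannot be assigned to a single change.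

Compound 4 `Fc1ccc(C(c2ccc(F)cc2)C2CCN(CCCOc3ccccc3)CC2)cc1` has not yet been measured in this assay. It differs from compound 3 in one place: phenyl in place of 4-carboxy-2-methoxyphenyl on an oxygen on a saturated carbon. The hydrogen-bond donor and acceptors counted in the leaving group are thereby removed. Because compound 3 gives 79.4 nM while compound 1, which carries no carboxy group on that ring, gives 3.16 nM, the change is expected to lower the number rather than raise it. The step this estimate means, a 7.9-fold lower number from compound 3 to compound 4 (0.90 log units; beyond the scatter), is expected to lie beyond the scatter. Compound 4 is expected to give 10 nM in this assay, within a range from 2 nM to 50 nM.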

Compound 4, dissociation constant: 1.59 nM
Estimate against measurement, compound 4: 6.3-fold (0.80 log units) above; measured number outside the range, below it.
By their numbers in this assay, from the lowest: compounds 4 and 1 (each within the scatter of the next); then compounds 2 and 3 (each within the scatter of the next).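

Setting phenyl in place of 4-carboxy-2-methoxyphenyl on an oxygen on a saturated carbon gives, in this assay, a 50-fold lower number from compound 3 to compound 4 (1.70 log units; beyond the scatter), and this is the first change in the series that can be read in one place. It shows that this position responds strongly to what is attached there, and that the bare phenyl, with 6 heavy atoms and no hydrogen-bond donors or acceptors, is enough for a low number, so neither the carboxy group nor the methoxy group is needed for it. Nothing measured here on these compounds accounts for the size of the step.

The step removes the carboxy group and the methoxy group together, so the compounds shown cannot divide it between them, and a ring carrying only one of the two would be needed to do so. Going by these compounds, it also remains open whether the large step belongs to the carboxylic acid itself or would persist with a methyl ester, a primary amide or a hydroxy group in its place.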